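Nitro in Place of Hydroxy: Expected Cytotoxicity on Vero Cells

This account rests on a few compounds, and the source may have more. Where it says the series, first, only, none or still open, it means among the compounds named here.

Of the compounds shown here, two sharing one core have been measured. Compound 1 `COc1ccc(C2SCC(=O)N2CCN2CCCCC2)cc1` carries a methoxy group, and in an ADME assay on Vero cells (Chlorocebus sabaeus) for cytotoxicity, read by neutral red uptake, tested at 3150 ug/mL (on this read-out lower numbers stand for a stronger effect and higher numbers for a weaker effect at the one concentration tested), compound 1 gives 11%. Compound 2 `O=C1CSC(c2ccc(O)cc2)N1CCN1CCCCC1` carries a hydroxy group in its place, and in this assay compound 2 gives 10%. For the measured compounds named here, the only step between measured compounds is a number 1 percentage points lower from compound 1 to compound 2 (within the scatter), so the two numbers are indistinguishable, and compound 2 stands beside compound 1 with no order between them.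

Compound 3 `O=C1CSC(c2ccc([N+](=O)[O-])cc2)N1CCN1CCCCC1` is the next member. The change from compound 2 to compound 3 is nitro in place of hydroxy on an aromatic carbon. Going by the values given here, no measured step introduces a nitro group, so the only guide is the methyl-to-hydrogen step on the oxygen, which was within the scatter. Among the compounds with values here, the single measured step at this position was small, and on that basis a step of a number 2 percentage points higher from compound 2 to compound 3 (within the scatter) is expected, with no movement beyond the scatter.

Compound 3 is therefore estimated at 12% in this assay. For compound 3 the expected range runs from 3% to 30%.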

Compound 3, a percentage reported as activity, at one concentration (the size of the read-out at that concentration, not a potency): 10%
The estimate for compound 3 lay 2 percentage points above the measured number, and the stated range covers the measured number.
By their numbers in this assay, from the lowest: compounds 2, 3 and 1 (each within the scatter of the next).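

In this assay, putting nitro in place of hydroxy on the aromatic carbon gives no change at the digits printed from compound 2 to compound 3 (within the scatter), and putting nitro in place of methoxy gives a number 1 percentage points lower from compound 1 to compound 3 (within the scatter). The earlier compounds had shown only that two oxygen-linked groups read alike at this position, whereas these steps extend that to a group of a different kind: nitro brings 3 heavy atoms, including a nitrogen, and 0 hydrogen-bond donors where hydroxy brought 1 heavy atom and 1 donor, and still no step among compounds 1, 2 and 3 leaves the scatter. Nothing at hand explains why these three substituents, each para to a large group, read alike.

Going by these compounds, whether an amine or a carboxylic acid on the same aromatic carbon would also stay within the scatter of these three compounds remains open, as does the effect of a longer chain there. Since the read-out comes from one concentration only, the compounds shown also leave open whether these three would still read alike at other concentrations.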